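The source may report more compounds than this note shows. Statements on the series, on what has been measured and on what is new or still open speak of the compounds shown alone.

In an ADME assay on cells (spleen, Mus musculus, strain C57BL/6) for inhibition, read by flow cytometry and propidium iodide staining, with a stated time of 24 h, at 37 degrees C (on this read-out lower numbers stand for an effect already at smaller amounts and higher numbers for an effect only at larger amounts of compound), compound 2 `O=C(O)CCCCc1cn(CC(=O)NCc2ccccc2)nn1` gives 1080 uM and compound 1 `CCC(O)Cc1cn(CC(=O)NCc2ccccc2)nn1` gives 630 uM, so the two stand within the scatter of each other. Compound 3 `Nc1cccc(-c2cn(CC(=O)NCc3ccccc3)nn2)c1` differs from compound 2 by 3-aminophenyl in place of 4-carboxybutyl on an aromatic carbon. Going by the values given here, the one measured step, a 1.7-fold higher number from compound 1 to compound 2 (0.23 log units; within the scatter), exchanges one chain for another and stays within the scatter. Among the compounds with values here, no measured step brings in an aromatic ring, so this step is only a weak guide. No change beyond the scatter is expected in this assay, in either direction. The expected step is a 1.5-fold lower number from compound 2 to compound 3 (0.19 log units; within the scatter). For compound 3 the estimate is 700 uM, with an expected range of 250 uM to 1500 uM.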

Compound 3, concentration for half-maximal effect: 800 uM
Compound 3: the middle estimate sits 1.1-fold (0.06 log units) below what was measured, and the stated range covers the measured number.
By their numbers in this assay, from the lowest: compounds 1, 3 and 2 (each within the scatter of the next).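

Placing an aromatic ring on the aromatic carbon, 3-aminophenyl gives a 1.4-fold lower number from compound 2 to compound 3 (0.13 log units; within the scatter) against 4-carboxybutyl and a 1.3-fold higher number from compound 1 to compound 3 (0.10 log units; within the scatter) against 2-hydroxybutyl in this assay. This position therefore tolerates a six-membered aromatic ring as well as an open chain, with no change beyond the scatter. No measurement explains this result.

Still open, going by these compounds, is whether any group at this position moves the number beyond the scatter, for example a plain phenyl, a phenyl bearing a carboxylic acid, or a much longer chain.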